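Swapping butyl for a ring group on the aromatic nitrogen

The compounds below may be only part of what the source reports. "The series", "measured", "known", "first", "only" and "open" are said of these compounds alone.

Within the data shown here, in a functional assay (B cells) with Mus musculus as the target (on this read-out lower numbers stand for an effect already at smaller amounts and higher numbers for an effect only at larger amounts of compound), compound 2 `C=CCn1c(=O)n(CCCC)c2nc(N)nc(O)c21` gives 2 uM, the lower of the two numbers so far, while compound 1 `C=CCn1c(=O)n([C@H]2CO[C@@H](CO)C2)c2nc(N)nc(O)c21` gives 83 uM. Compound 3 `C=CCn1c(=O)n(C2C=CC(CO)O2)c2nc(N)nc(O)c21` differs from compound 2 by a group of 7 heavy atoms (5 carbon, 2 oxygen; one five-membered non-aromatic ring with 1 hetero atom) in place of a group of 4 heavy atoms (4 carbon; no ring), on an aromatic nitrogen. Among the measured compounds shown here, the one measured step bearing on this is a 42-fold lower number from compound 1 to compound 2 (1.62 log units; beyond the scatter), where butyl likewise took the place of a five-membered non-aromatic ring group, one without the double bond. The change to compound 3 runs the opposite way, so the expected step is a 30-fold higher number from compound 2 to compound 3 (1.48 log units; beyond the scatter), large and towards a higher number. Compound 3 is estimated at 60 uM, with an expected range of 20 uM to 180 uM.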

Compound 3, concentration for half-maximal effect: 6 uM
Compound 3: the middle estimate sits 10-fold (1.00 log units) above what was measured; the measured number lies below the stated range.
By their numbers in this assay, from the lowest: compound 2; then compound 3; then compound 1.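

In this assay a ring group on the aromatic nitrogen need not cost as much as the first pair suggested: replacing butyl gives only a 3.0-fold higher number from compound 2 to compound 3 (0.48 log units; beyond the scatter) here, and butyl still holds the lowest number of the three. The two ring groups are not interchangeable, though they match in heavy-atom count, since the swap between them gives a 14-fold lower number from compound 1 to compound 3 (1.14 log units; beyond the scatter) at this position. Nothing available explains the gap between the two ring groups. Still open, from the compounds shown here alone, is how a longer chain than butyl, or a butyl chain ending in an amine or a carboxylic acid, would compare with compound 2.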